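Removing the Amide Methyl of Compound 1

This account rests on a few compounds, and the source may have more. Where it says the series, first, only, none or still open, it means among the compounds named here.

Compound 1 `CNC(=O)/C=C/c1ccncc1-c1ccc2ccccc2c1` gives 8680 nM in a functional assay on MDA-MB-231 cells (Homo sapiens) for inhibition, read by sulforhodamine B assay, with a stated time of 72 h; a higher number here means a weaker inhibitor of growth, a lower number a stronger inhibitor of growth. Compound 2 `O=C(/C=C/c1ccncc1-c1ccc2cc[nH]c2c1)N1CCOCC1` gives only an assay limit, > 10000 nM.

Among the compounds with values here, compound 1 thus holds the only actual number in this assay; the other reading sits at the limit of > 10000 nM in this assay, at which 1 of the 2 values shown sits. Compound 3 `NC(=O)/C=C/c1ccncc1-c1ccc2ccccc2c1` differs from compound 1 by hydrogen in place of methyl on an amide-type nitrogen, methylcarbamoyl becoming carbamoyl. Within the data shown here, no measured pair of this kind is available, so no shift beyond the usual scatter is expected in this assay. Compound 3 is estimated at 9500 nM, with a range of 4000 nM to 22000 nM. The expected step of a 1.1-fold higher number from compound 1 to compound 3 (0.04 log units; within the scatter) is essentially none, and a limit reading is quite possible.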

Compound 3, concentration for 50% growth inhibition: > 10000 nM
Compound 3: no number, only a limit; the forecaster's own chance of this, stated with the estimate: 40%; middle value at least 1.0-fold (0.02 log units) away from the limit.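

Compound 3 gives > 10000 nM in this assay, a limit and not a number. Hydrogen in place of methyl on the amide-type nitrogen gives an at least 1.1-fold higher number from compound 1 to compound 3 (0.06 log units; that floor lies within the scatter), so the change brings no readable gain in growth inhibition, and its true size stays undetermined, since the floor does not exclude a larger loss. Readings at the limit now form the larger share of the values: the limit of > 10000 nM in this assay, at which 2 of the 3 values shown sit.

On these data alone, whether a longer chain such as ethyl on this nitrogen would give a number inside the range of the assay remains open. So does the question of how a hydroxyethyl group there would read.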